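A few compounds are considered here, and "the series" means these few. Any claim that something is new, unique, unknown or untested is made for them only; others in the source may bear on it.

Working notes on the series. In a functional assay on MCF7 cells (Homo sapiens) for inhibition, read by MTT assay, with a stated time of 96 h (a higher number here means a weaker inhibitor of growth, a lower number a stronger inhibitor of growth), compound 1 (`CCCC(=O)SCCCCCCNC(=O)c1cc(-c2ccncc2)n[nH]1`) gives 12100 nM and compound 2 (`CC(=O)SCCCCCCNC(=O)c1cc(-c2ccncc2)n[nH]1`) gives 24900 nM. Compound 2 therefore holds the higher of the two numbers and is the weaker growth inhibitor of the pair.

The next structure, compound 3 (`CSCCCCCCNC(=O)c1cc(-c2ccncc2)n[nH]1`), has methyl in place of acetyl on a sulfur, so acetylsulfanyl becomes methylsulfanyl: methyl in place of acetyl on a sulfur.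

Among the measured compounds shown here, only one measured step bears on this change, and it is an indirect guide: a 2.1-fold higher number from compound 1 to compound 2 (0.31 log units; beyond the scatter). That modest step comes from hydrogen in place of ethyl on a saturated chain carbon bound to a carbonyl carbon, and the carbonyl stays in both compounds. For the measured compounds named here, compound 3 loses the carbonyl itself, and no measured compound lacks it, so the size of this change remains poorly constrained. Shortening the group on the carbonyl raised the number from compound 1 to compound 2, so a modest further rise is tentatively expected in this assay, with a wide margin.

The expected change is a 2.2-fold higher number from compound 2 to compound 3 (0.34 log units; beyond the scatter). For compound 3 the estimated value is 55000 nM, with an expected range of 20000 nM to 150000 nM.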

Compound 3, concentration for 50% growth inhibition: > 50000 nM
Compound 3: no number, only a limit (the forecaster's own chance of this, stated with the estimate: 25%); the middle value does not contradict the limit.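

In this assay compound 3 gives > 50000 nM, which is a limit of the assay and not a number. On the sulfur, methyl in place of acetyl gives an at least 2.0-fold higher number from compound 2 to compound 3 (0.30 log units; that floor lies within the scatter), a floor that cannot be told apart from the scatter on its own, while methyl in place of propylcarbonyl gives an at least 4.1-fold higher number from compound 1 to compound 3 (0.61 log units; beyond the scatter), so the firm reading of this change comes from the comparison with the longer acyl group. Compound 3 is the first compound shown with no carbonyl on the sulfur, and the true size of both steps remains unread at the limit: the limit of > 50000 nM in this assay, at which 1 of the 3 values shown sits.

The compounds shown do not separate the loss of the carbonyl from the shortening of the group on the sulfur, and they give no measured number for any compound without that carbonyl. A free thiol, or a longer alkyl chain on the sulfur such as hexyl, would be needed to tell whether the carbonyl itself or the size of the group governs the number in this assay.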